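Swapping 2-hydroxyphenyl for 2,4-dichlorophenyl on the shared core

The compounds below may be only part of what the source reports. "The series", "measured", "known", "first", "only" and "open" are said of these compounds alone.

In a functional assay on BGC-823 cells (Homo sapiens) for cytotoxicity, read by MTT assay, with a stated time of 48 h (a higher number here means a weaker inhibitor, a lower number a stronger inhibitor), compound 1 `O=C(CSc1nnc(-c2ccncc2)o1)N/N=C/c1ccc([N+](=O)[O-])cc1` gives 31500 nM and compound 2 `O=C(CSc1nnc(-c2ccncc2)o1)N/N=C/c1ccccc1O` gives 6160 nM as the lower of the two numbers. Compound 3 `O=C(CSc1nnc(-c2ccncc2)o1)N/N=C/c1ccc(Cl)cc1Cl` differs from compound 2 on the carbon with a double bond to nitrogen: 2,4-dichlorophenyl in place of 2-hydroxyphenyl on a carbon with a double bond to nitrogen is the change. Going by the values given here, one measured step bears on it: a 5.1-fold lower number from compound 1 to compound 2 (0.71 log units; beyond the scatter) at the same place, a modest step. Among the compounds with values here, no chlorine-bearing compound has been measured, so a modest move to a higher number is expected in this assay with low confidence. The expected step is a 1.9-fold higher number from compound 2 to compound 3 (0.29 log units; within the scatter) as a working figure. Compound 3 is estimated at 12000 nM within a range of 3500 nM to 40000 nM for now.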

Compound 3, half-maximal inhibitory concentration: 35600 nM
Beside the measured number, compound 3's estimate is 3.0-fold (0.47 log units) below it; the measured number falls inside the stated range.
By their numbers in this assay, from the lowest: compound 2; then compounds 1 and 3 (each within the scatter of the next).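

At the carbon with a double bond to nitrogen, replacing 2-hydroxyphenyl with 2,4-dichlorophenyl gives a 5.8-fold higher number from compound 2 to compound 3 (0.76 log units; beyond the scatter), so the gain seen with 2-hydroxyphenyl does not carry over to this group. Replacing 4-nitrophenyl with 2,4-dichlorophenyl gives a 1.1-fold higher number from compound 1 to compound 3 (0.05 log units; within the scatter), which leaves these two groups unseparated and 2-hydroxyphenyl alone apart from both. No supporting data accompany these numbers to explain the difference.

Open, going by these compounds, is whether 2-aminophenyl or 4-hydroxyphenyl at this place would read like 2-hydroxyphenyl. Unsubstituted phenyl also remains open as a reference point for all three groups.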